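A few compounds are considered here, and "the series" means these few. Any claim that something is new, unique, unknown or untested is made for them only; others in the source may bear on it.

Measured so far in a functional assay for activation of Alpha-1A adrenergic receptor (Homo sapiens), read by calcium flux; on this read-out lower numbers stand for an effect already at smaller amounts and higher numbers for an effect only at larger amounts of compound:

- compound 1 `Cc1ncc(-c2ccccc2NCC2=NCCN2)o1`: 110 nM
- compound 2 `Cc1cc(-c2ccccc2NCC2=NCCN2)on1`: 38.9 nM
- compound 3 `Cc1ccc(-c2ccccc2NCC2=NCCN2)o1`: 2.69 nM

Compound 3 gives the lowest number of the three. It is set apart from the nearest compound by the step of a 14-fold lower number from compound 2 to compound 3 (1.16 log units; beyond the scatter) and from the furthest by the step of a 41-fold lower number from compound 1 to compound 3 (1.61 log units; beyond the scatter); both steps lie beyond the scatter.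

Compound 4 `CC/C(=N\OC)c1ccccc1NCC1=NCCN1` differs from compound 3 in one place: a group of 6 heavy atoms (4 carbon, 1 nitrogen, 1 oxygen; no ring) in place of a group of 6 heavy atoms (5 carbon, 1 oxygen; one five-membered aromatic ring with 1 hetero atom), on an aromatic carbon. Within the data shown here, none of the measured steps swaps a ring for a group without a ring. The steps of a 2.8-fold lower number from compound 1 to compound 2 (0.45 log units; beyond the scatter), a 41-fold lower number from compound 1 to compound 3 (1.61 log units; beyond the scatter) and a 14-fold lower number from compound 2 to compound 3 (1.16 log units; beyond the scatter) all exchange one five-membered aromatic ring for another at this same place, and two of them were large, so this place clearly matters, but they give no direction for a group with no ring. Since compound 3 already holds the lowest number, a move back toward higher numbers seems the more likely outcome, with wide uncertainty. For compound 4 the expected value in this assay is 30 nM, within a range of 4 nM to 250 nM. This estimate corresponds to an expected step of an 11-fold higher number from compound 3 to compound 4 (1.05 log units; beyond the scatter).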

Compound 4, half-maximal effective concentration: 3.31 nM
Compound 4: middle estimate off by 9.1-fold (0.96 log units), on the high side; the whole stated range lies above it.
By their numbers in this assay, from the lowest: compounds 3 and 4 (each within the scatter of the next); then compound 2; then compound 1.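

A group with no ring can take the place of 5-methylfuran-2-yl on this aromatic carbon, and in this assay the change stays within the scatter (a 1.2-fold higher number from compound 3 to compound 4 (0.09 log units; within the scatter)). The same group also gives large steps from the two rings with two hetero atoms (a 12-fold lower number from compound 2 to compound 4 (1.07 log units; beyond the scatter)) and (a 33-fold lower number from compound 1 to compound 4 (1.52 log units; beyond the scatter)), so among these compounds a ring is not needed for a low number, and the higher numbers belong to those two rings rather than to rings in general. Nothing available explains these differences.

From the compounds shown here alone, it remains open whether a number this low would survive with an amine or a carboxylic acid on this carbon, or with a longer chain in the new group. Going by these compounds, the role of its double bond also remains open.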